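The source may hold more compounds than are shown below. What is called first, only, known or untested is meant among the compounds shown, and "the series" means these compounds.

Compound 2 `O=C(COc1cccc2ccccc12)N/N=C/c1cccc(O)c1` gives 62.7 ug/mL in an ADME assay on HEL cells (Homo sapiens) for cytotoxicity (a higher number here means that more compound is tolerated, a lower number that less compound is tolerated), and stands at the top of the three measured numbers. Compound 3 `COc1cc(/C=N/NC(=O)COc2cccc3ccccc23)cc(OC)c1O` gives 52.8 ug/mL, which lies within the scatter of compound 2; compound 1 `CCOc1ccc(/C=N/NC(=O)COc2cccc3ccccc23)cc1O` gives 18.1 ug/mL, which lies beyond it. Among the compounds with values here, the one single-point step known is a 3.5-fold higher number from compound 1 to compound 2 (0.54 log units; beyond the scatter).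

Compound 4 `Cc1ccc(/C=N/NC(=O)COc2cccc3ccccc23)cc1` differs from compound 2 by 4-methylphenyl in place of 3-hydroxyphenyl on a carbon with a double bond to nitrogen. Within the data shown here, no measured step touches this part of the shared core, and the step from compound 1 to compound 2 concerns a different group, so it bears on compound 4 only loosely. Among the measured compounds shown here, with no direct precedent, no step beyond the scatter is expected in this assay from compound 2 to compound 4; compound 4 is estimated at 45 ug/mL with a range of 18 ug/mL to 110 ug/mL, which means an expected step of a 1.4-fold lower number from compound 2 to compound 4 (0.14 log units; within the scatter).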

Compound 4, half-maximal cytotoxic concentration: 80.1 ug/mL
Compound 4: middle estimate off by 1.8-fold (0.25 log units), on the low side; measured number inside the range.
By their numbers in this assay, from the lowest: compound 1; then compounds 3, 2 and 4 (each within the scatter of the next).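

Replacing 3-hydroxyphenyl with 4-methylphenyl on a carbon with a double bond to nitrogen gives a 1.3-fold higher number from compound 2 to compound 4 (0.11 log units; within the scatter) in this assay. This place therefore accepts a group with no hydrogen-bond donor or acceptor without a step beyond the scatter, at least for this pair. Nothing on hand accounts for the step.

This single pair cannot separate the change of substituent from the change in its placement on the ring. From the compounds shown here alone, how an aminophenyl or a carboxyphenyl group would behave at this place remains open.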